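This account rests on a few compounds, and the source may have more. Where it says the series, first, only, none or still open, it means among the compounds named here.

Measured so far:
- Compound 1 `CC[C@@H]1CC[C@@H](C(=O)N2CCOCC2)N1C(=O)C1=C(C(C)C)N2C(=N[C@@](C)(c3ccc(Cl)cc3)[C@H]2c2ccc(Cl)cc2)S1` gives 9 ug/mL in a physicochemical assay for solubility, read by HPLC, in phosphate buffer, at pH 6.8; a lower number here means a less soluble compound, a higher number a more soluble compound
- Compound 2 `CC[C@@H]1CC[C@@H](C(=O)N2CCN(C)[C@H](C)C2)N1C(=O)C1=C(C(C)C)N2C(=N[C@@](C)(c3ccc(Cl)cc3)[C@H]2c2ccc(Cl)cc2)S1` gives 14 ug/mL in this assay

Compound 2 stands level with compound 1, since the two values lie within the scatter of each other. Going by the values given here, the single measured step is a 1.6-fold higher number from compound 1 to compound 2 (0.19 log units; within the scatter) with 3,4-dimethylpiperazin-1-yl in place of morpholin-4-yl on a carbonyl carbon.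

Compound 3 `CC[C@@H]1CC[C@@H](C(=O)N2CCN(C)[C@@H](C)C2)N1C(=O)C1=C(C(C)C)N2C(=N[C@@](C)(c3ccc(Cl)cc3)[C@H]2c2ccc(Cl)cc2)S1` relates to compound 2 as follows: the two compounds have the same atoms and bonds and differ only in configuration as drawn: 1 of 5 stereo elements differ; a stereocentre at a saturated ring carbon is drawn R in compound 2 and S in compound 3 and a stereocentre at a saturated ring carbon is drawn R in compound 2 and S in compound 3. Among the compounds with values here, no measured step concerns configuration alone, so that one step, an exchange of a whole group, is the only guide. The starting point in this assay is the value of compound 2 at 14 ug/mL, and the step from it is expected to stay within the scatter. The estimated step is no change at the digits printed from compound 2 to compound 3 (within the scatter) and so no real change. Compound 3 is expected at 14 ug/mL with an estimated range from 7 ug/mL to 28 ug/mL for repeated measurements.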

Compound 3, solubility: 16 ug/mL
Compound 3: the middle estimate sits 1.1-fold (0.06 log units) below what was measured, and the stated range covers the measured number.
By their numbers in this assay, from the lowest: compounds 1, 2 and 3 (each within the scatter of the next).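

In this assay, going by these compounds alone, this pair gives the only reading of configuration alone: inverting one stereocentre at a saturated ring carbon gives a 1.1-fold higher number from compound 2 to compound 3 (0.06 log units; within the scatter). All other stereo elements, atoms and bonds stay fixed, so the pair isolates that one stereocentre: the fact that compounds 2 and 3 differ only in the configuration as drawn. With the other configuration, 3,4-dimethylpiperazin-1-yl in place of morpholin-4-yl on a carbonyl carbon also remains within the scatter, giving a 1.8-fold higher number from compound 1 to compound 3 (0.25 log units; within the scatter).

As far as these compounds go, it remains open whether any replacement on that carbonyl carbon, such as a group carrying a carboxylic acid or a primary amine, would give a step beyond the scatter in this assay. From the compounds shown here alone, it is also open whether inverting a stereocentre would again give a step within the scatter if the ring methyl were replaced by a longer chain.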